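A Methoxy Group Gives Way to Hydroxy

The source may report more compounds than this note shows. Statements on the series, on what has been measured and on what is new or still open speak of the compounds shown alone.

Of the compounds shown here, two have been measured. Compound 1 `COc1cc(Cl)cc(-c2nn(-c3cccc(NC(=O)Nc4ccc(Cl)c(C(F)(F)F)c4)c3)cc2-c2ccncc2)c1` was tested in a functional assay on NCI-H522 cells (Homo sapiens) for inhibition, read by sulforhodamine B assay, with a stated time of 48 h, tested at 0.1 uM (a higher number here means a weaker effect of the compound at the concentration tested, a lower number a stronger effect), where compound 1 gives 77%. Compound 2 `COc1cc(Cl)cc(-c2nn(-c3cccc(NC(=O)c4cccc(C(F)(F)F)c4)c3)cc2-c2ccncc2)c1` differs from it only at the carbonyl carbon; in this assay compound 2 gives 83%. The step of a number 6 percentage points higher from compound 1 to compound 2 (within the scatter) lies within the scatter, so compound 1 stands at one of two numbers that cannot be told apart from each other. Compound 3 `O=C(Nc1cccc(-n2cc(-c3ccncc3)c(-c3cc(O)cc(Cl)c3)n2)c1)Nc1ccc(Cl)c(C(F)(F)F)c1` keeps everything in compound 1 except one small change: hydrogen in place of methyl on an oxygen on an aromatic ring. Among the compounds with values here, no measured step involves this oxygen, so the only guide is that the single step measured, on another part of the structure, moved nothing beyond the scatter. A step of a number 2 percentage points lower from compound 1 to compound 3 (within the scatter) is therefore expected, meaning none beyond the usual scatter. Compound 3 is estimated at 75%, with a range from 58% to 92%.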

Compound 3, a percentage reported as activity, at one concentration (the size of the read-out at that concentration, not a potency): 83%
Estimate against measurement, compound 3: 8 percentage points below; the measured number falls inside the stated range.
By their numbers in this assay, from the lowest: compounds 1, 2 and 3 (each within the scatter of the next).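

At this oxygen, the change from methoxy to hydroxy gives a number 6 percentage points higher from compound 1 to compound 3 (within the scatter) in this assay and so, at this one concentration, removing the methyl does not shift the read-out by more than repeat measurements would. Within the data shown here, the earlier step lay on another part of the structure, which makes this the first reading at this oxygen, and it shows that a free hydroxy and a methoxy cannot be told apart here. Nothing shown explains this result.

On these data alone, whether an amine in place of the hydroxy, or a longer chain such as an ethoxy or propoxy group on the same oxygen, would move the number beyond the scatter remains open. Also open, as far as these compounds go, is whether compound 1 and compound 3 would stay this close at other concentrations, since a single-concentration read-out is not a potency.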